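From 4-methylphenyl to 4-nitrophenyl: compound 3 to compound 4

This account rests on a few compounds, and the source may have more. Where it says the series, first, only, none or still open, it means among the compounds named here.

Measured in a functional assay on HeLa cells (Homo sapiens) for antiproliferative activity, read by MTT assay, with a stated time of 48 h; a lower number here means a stronger inhibitor, a higher number a weaker inhibitor:
- compound 1 `O=[N+]([O-])c1cccc(-c2nn(-c3ccccc3)cc2C(Nc2nc3ccccc3s2)c2c(O)ccc3ccccc23)c1` (8220 nM)
- compound 2 `Cc1ccc2nc(NC(c3cn(-c4ccccc4)nc3-c3cccc(Cl)c3)c3c(O)ccc4ccccc34)sc2c1` (9430 nM)
- compound 3 `Cc1ccc(-c2nn(-c3ccccc3)cc2C(Nc2nc3cc(C)c(C)cc3s2)c2c(O)ccc3ccccc23)cc1` (17800 nM)

Compound 3 (17800 nM) lies within the scatter of compound 2, while its number is higher than that of compound 1 by a gap beyond the scatter. Compound 4 `Cc1cc2nc(NC(c3cn(-c4ccccc4)nc3-c3ccc([N+](=O)[O-])cc3)c3c(O)ccc4ccccc34)sc2cc1C` has not yet been measured. It carries nitro in place of methyl on an aromatic carbon, para to a large group (nitro in place of methyl on an aromatic carbon). Within the data shown here, no measured pair isolates this change. Among the measured compounds shown here, the only guide is compound 1 (8220 nM), which also bears a nitro group but differs elsewhere. The expected change is modest (a 1.8-fold lower number from compound 3 to compound 4 (0.25 log units; within the scatter)), toward a lower number and not beyond the scatter. Compound 4 is estimated at 10000 nM in this assay (expected range 4000 nM to 25000 nM).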

Compound 4, half-maximal inhibitory concentration: 14700 nM
Compound 4: the middle estimate sits 1.5-fold (0.17 log units) below what was measured; the range from low to high includes it.
By their numbers in this assay, from the lowest: compounds 1, 2, 4 and 3 (each within the scatter of the next, the first and the last beyond it).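

In this assay, putting nitro in place of methyl on an aromatic carbon, para to a large group, gives a 1.2-fold lower number from compound 3 to compound 4 (0.08 log units; within the scatter) and so leaves the number within the scatter. Among these compounds, this is the first comparison here of compounds that differ in one place, and it shows no measurable separation between 4-methylphenyl and 4-nitrophenyl at this position. Nothing available explains this result.

Going by these compounds, whether an amine or a carboxylic acid in this place would move the number beyond the scatter remains open. So does whether nitro would give the same result with the other groups on the shared core.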